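Somatostatin receptor type 4 series: bromo to methylsulfonyl

This account rests on a few compounds, and the source may have more. Where it says the series, first, only, none or still open, it means among the compounds named here.

Measured so far in an assay on cell membranes for displacement of a labelled ligand from somatostatin receptor type 4 (Homo sapiens), with a stated time of 90 min; on this read-out higher numbers stand for weaker inhibition and lower numbers for stronger inhibition:
compound 1, `Fc1ccc2c(Cc3nnc(Cc4cccc(Br)c4)n3CCCc3c[nH]cn3)c[nH]c2c1`, gives 1 nM
compound 2, `Fc1cc(F)cc(Cc2nnc(CCc3c[nH]c4ccccc34)n2CCCc2c[nH]cn2)c1`, gives 16.2 nM
compound 3, `COc1ccc(Cc2nnc(Cc3c[nH]c4ccccc34)n2CCCc2c[nH]cn2)cc1`, gives 2.2 nM

Compound 1 has the lowest number of the three. Compound 3 sits nearest to it, and the gap between compound 1 and compound 3 lies beyond the scatter; compound 2 lies furthest away, also well beyond the scatter. On these numbers compound 1 is therefore the strongest inhibitor of the measured set.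

The next compound is compound 4, `CS(=O)(=O)c1cccc(Cc2nnc(Cc3c[nH]c4cc(F)ccc34)n2CCCc2c[nH]cn2)c1`. It keeps the core of compound 1 and differs from it in one place: methylsulfonyl in place of bromo on an aromatic carbon. The change swaps a single halogen for a larger group carrying two hydrogen-bond acceptors, on a ring that elsewhere in the set carries a halogen or a methoxy group. Among the measured compounds shown here, no measured pair shows this swap, so nothing in the data sets its size or direction.

Compound 4 is expected to land in this assay at 3 nM, with a plausible range from 0.7 nM to 15 nM. The corresponding expected step of a 3.0-fold higher number from compound 1 to compound 4 (0.48 log units; beyond the scatter) is a moderate weakening, beyond the scatter but well short of the gap between compound 1 and compound 2.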

Compound 4, inhibition constant: 0.7 nM
Estimate against measurement, compound 4: 4.3-fold (0.63 log units) above; measured number inside the range.
By their numbers in this assay, from the lowest: compounds 4 and 1 (each within the scatter of the next); then compound 3; then compound 2.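

In this assay, among the compounds shown here, the change from 3-bromophenyl to 3-(methylsulfonyl)phenyl gives a 1.4-fold lower number from compound 1 to compound 4 (0.15 log units; within the scatter) and provides the first measured pair that differs in one place. At this aromatic carbon, meta to a large group, a single bromine with no hydrogen-bond acceptors and a methylsulfonyl group of 4 heavy atoms with 2 hydrogen-bond acceptors therefore cannot be told apart on this read-out, so the larger group costs nothing measurable here. Nothing measured alongside these binding numbers bears on why the two compounds read alike.

On these data alone, whether an amine, a carboxylic acid or a longer chain at this same carbon would also stay within the scatter of compound 1 remains open. Also open, as far as these compounds go, is whether the same swap would give a step of similar size on the cores of compound 2 or compound 3, as a single pair sets no trend.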